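Thiophene swap at the chain end of compound 2

The source may report more compounds than this note shows. Statements on the series, on what has been measured and on what is new or still open speak of the compounds shown alone.

Among the measured compounds shown here, in a functional assay on MCF7 cells (Homo sapiens) for cytotoxicity (on this read-out higher numbers stand for weaker inhibition and lower numbers for stronger inhibition), two compounds on the shared core have numbers so far. Compound 1 (`C=C/C=C\[C@H](C)[C@H](OC(N)=O)[C@@H](C)[C@H](O)[C@@H](C)C/C(C)=C\[C@H](C)[C@@H](O)[C@@H](C)/C=C\CCc1ccc(Oc2ccccc2)cc1`) gives 4000 nM in this read-out. Compound 2 (`C=C/C=C\[C@H](C)[C@H](OC(N)=O)[C@@H](C)[C@H](O)[C@@H](C)C/C(C)=C\[C@H](C)[C@@H](O)[C@@H](C)/C=C\CCc1cccc(Cl)c1`) gives 400 nM and holds the lower of the two numbers, so it is the stronger inhibitor of the pair, by a gap beyond the scatter.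

Compound 3 (`C=C/C=C\[C@H](C)[C@H](OC(N)=O)[C@@H](C)[C@H](O)[C@@H](C)C/C(C)=C\[C@H](C)[C@@H](O)[C@@H](C)/C=C\CCc1ccsc1`) is still unmeasured. It carries thiophen-3-yl in place of the 3-chlorophenyl of compound 2, on a saturated chain carbon, two bonds along the chain from a double-bonded chain carbon (thiophen-3-yl in place of 3-chlorophenyl on a saturated chain carbon, two bonds along the chain from a double-bonded chain carbon).

For the measured compounds named here, no measured pair isolates this exchange, so the expectation is loose and rests only on the two values in hand and on the counted change. A small move toward a higher number, meaning weaker inhibition, is expected, not clearly beyond the scatter. The expected step is a 1.8-fold higher number from compound 2 to compound 3 (0.24 log units; within the scatter) in this assay on this estimate. Compound 3 is estimated at 700 nM with an expected range of 200 nM to 2500 nM in this read-out.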

Compound 3, half-maximal inhibitory concentration: 850 nM
For compound 3 the middle estimate is 1.2-fold (0.08 log units) below the measured one; the range from low to high includes it.
By their numbers in this assay, from the lowest: compound 2; then compound 3; then compound 1.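

In this assay, thiophen-3-yl in place of 3-chlorophenyl on a saturated chain carbon, two bonds along the chain from a double-bonded chain carbon, gives a 2.1-fold higher number from compound 2 to compound 3 (0.33 log units; beyond the scatter) as the first step read at this position. The step is modest, so this position accepts a five-membered aromatic ring with 1 hetero atom as well as a six-membered aromatic ring of carbon only, at some cost in this read-out. The exchange alters ring size, removes the chlorine and brings in the sulfur all at once, and no supporting data are available to tie the step to any one of these changes or to give it a cause.

Open, from the compounds shown here alone, is how the step divides between loss of the chlorine and change of ring, a question that unsubstituted phenyl on the same chain would separate from the thiophen-3-yl result. Also open, going by these compounds, is how pyridin-3-yl, thiophen-2-yl or a longer chain carrying thiophen-3-yl would read at this position on the shared core.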